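Piperidinyl-to-methyl swap on a pyrazole, carried to a second core

The source may hold more compounds than are shown below. What is called first, only, known or untested is meant among the compounds shown, and "the series" means these compounds.

Compound 1 `CC(Oc1ncnc2ccc(-c3cnn(C4CCNCC4)c3)cc12)c1c(Cl)ccc(F)c1Cl`: 6770 nM
Compound 2 `c1cnc2ccc(Nc3ncnc4ccc(-c5cnn(C6CCNCC6)c5)cc34)cc2c1`: 30300 nM
Compound 3 `CC(Oc1ncnc2ccc(-c3cnn(C)c3)cc12)c1c(Cl)ccc(F)c1Cl`: 30000 nM

Of the compounds shown here, three have been measured in a functional assay on MDA-MB-231 cells (Homo sapiens) for antiproliferative activity, read by MTT assay, with a stated time of 72 h; on this read-out higher numbers stand for weaker inhibition and lower numbers for stronger inhibition. Compound 1 gives 6770 nM, and compound 3, which carries methyl in place of piperidin-4-yl on an aromatic nitrogen, gives 30000 nM; the step of a 4.4-fold higher number from compound 1 to compound 3 (0.65 log units; beyond the scatter). Compound 2 gives 30300 nM, and its value and that of compound 3 lie within the scatter of each other, so nothing can be said about their order. The difference between the core of compound 1 and the core of compound 2 is not broken down here.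

Compound 4 `Cn1cc(-c2ccc3ncnc(Nc4ccc5ncccc5c4)c3c2)cn1` has not yet been measured. It differs from compound 2 by methyl in place of piperidin-4-yl on an aromatic nitrogen, the same change that was made from compound 1 to compound 3, at the same place. If that change behaves alike on the core of compound 2, a step of about a 3.6-fold higher number from compound 2 to compound 4 (0.56 log units; beyond the scatter) is expected, resting on a 4.4-fold higher number from compound 1 to compound 3 (0.65 log units; beyond the scatter). Because compound 2 already sits at 30300 nM, compound 4 is estimated at 110000 nM, plausibly between 35000 nM and 350000 nM.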

Compound 4, half-maximal inhibitory concentration: 26300 nM
Compound 4: middle estimate off by 4.2-fold (0.62 log units), on the high side, outside the stated range (below it).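

In this assay, replacing piperidin-4-yl with methyl on the core of compound 2 gives a 1.2-fold lower number from compound 2 to compound 4 (0.06 log units; within the scatter), so this pair shows no measurable effect of the change. The change therefore did not carry over from the core of compound 1 to the core of compound 2, and the two steps differ by more than the scatter allows: the same change on two cores in this assay, a 4.4-fold higher number (0.65 log units; beyond the scatter) from compound 1 to compound 3 and a 1.2-fold lower number (0.06 log units; within the scatter) from compound 2 to compound 4, 5.1-fold (0.71 log units) apart, beyond the scatter of two such steps This shows that the outcome of the change depends on the core in these two pairs, but it does not show what about the cores produces the difference, and two pairs set no rule for any other core in the series.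

The compounds shown leave open whether a different group on that aromatic nitrogen, such as a carboxylic acid or a longer chain ending in an amine, would give a readable step on the core of compound 2. They also leave open whether the same contrast between the two cores would appear in any other read-out.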